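A few compounds are considered here, and "the series" means these few. Any claim that something is new, unique, unknown or untested is made for them only; others in the source may bear on it.

Measured compounds:
compound 1, `O=C(NC1CCCCC1)c1c(NO)cc(-c2ccccc2)oc1=O`, 10500 nM
compound 2, `O=C(NC1CCCCC1)c1c(NO)cc(-c2ccc(F)cc2)oc1=O`, 11400 nM
compound 3, `O=C(Nc1ccccc1)c1c(NO)cc(-c2cccs2)oc1=O`, a limit, > 20000 nM

The three compounds were tested in an ADME assay on Huh-7 cells (Homo sapiens) for cytotoxicity, with a stated time of 3 days; a higher number here means that more compound is tolerated, a lower number that less compound is tolerated. Compound 1 gives 10500 nM and compound 2 gives 11400 nM; the two differ by fluoro in place of hydrogen on an aromatic carbon, and the step of a 1.1-fold higher number from compound 1 to compound 2 (0.04 log units; within the scatter), so the two values are not distinguished by this measurement. Compound 3 reaches only a limit of the assay, > 20000 nM, and (the limit of > 20000 nM in this assay, at which 1 of the 3 values shown sits). How compound 3 differs from compound 1 is not broken down here, as the two differ in more than one place.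

Compound 4, `O=C(Nc1ccc(F)cc1)c1c(NO)cc(-c2cccs2)oc1=O`, has not yet been measured. It differs from compound 3 by fluoro in place of hydrogen on an aromatic carbon. The change is described in the same words as that from compound 1 to compound 2, including the place at which the fluorine enters, so it is the same change made on another core. From that earlier step, which stayed within the scatter, no shift in tolerated concentration is expected from compound 3 to compound 4 either. Since compound 3 itself gave only a limit of > 20000 nM, compound 4 is expected to sit at or beyond the same limit, with the value estimated at 25000 nM and a range from 12000 nM to 60000 nM. In step terms this expectation amounts to a step that the limit leaves unreadable from compound 3 to compound 4, and a further limit reading is considered the most likely outcome.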

Compound 4, half-maximal cytotoxic concentration: > 20000 nM
Compound 4: no number, only a limit (the forecaster's own chance of this, stated with the estimate: 70%); the middle value lies beyond the limit too.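

In this assay compound 4 gives > 20000 nM as a limit of the assay, not a number. Among the compounds shown here, compound 3 stands at the same limit, so no step from compound 3 to compound 4 can be read: the limit of > 20000 nM in this assay, at which 2 of the 4 values shown sit. The compounds shown leave open how far beyond this limit compound 3 and compound 4 lie, and whether fluoro in place of hydrogen changes the tolerated concentration on this core.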